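From hydroxyalkyl to aminoalkyl on the sulfur chain

The compounds below may be only part of what the source reports. "The series", "measured", "known", "first", "only" and "open" are said of these compounds alone.

Measured so far in a functional assay on HT cells (Homo sapiens) for antiproliferative activity, read by fluorescence, with a stated time of 72 h; a higher number here means a weaker inhibitor of growth, a lower number a stronger inhibitor of growth
compound 1 `CC(O)CSc1nc(NCc2ccc(-c3ccccn3)cc2)c2[nH]nc(C(C)C)c2n1` gives 62 nM
compound 2 `CC(C)c1n[nH]c2c(NCc3ccc(-c4ccccn4)cc3)nc(SCCCO)nc12` gives 109 nM

Among the measured compounds shown here, compound 2 gives 109 nM and lies within the scatter of compound 1, the only other number available. Compound 3 `CC(C)c1n[nH]c2c(NCc3ccc(-c4ccccn4)cc3)nc(SCC(C)(C)N)nc12` carries 1-amino-1-methylethyl in place of 2-hydroxyethyl on a saturated chain carbon bound to a sulfur in the same shared core. For the measured compounds named here, the one measured step, a 1.8-fold higher number from compound 1 to compound 2 (0.25 log units; within the scatter), exchanged only one hydroxyethyl for another, and no measured compound carries an amino group, so it is a weak guide. No step beyond the scatter is therefore expected in this assay, and no direction can be firmly expected. The expected step is a 1.4-fold lower number from compound 2 to compound 3 (0.13 log units; within the scatter) for this change. The estimate for compound 3 is 80 nM within an expected range from 25 nM to 250 nM in this measurement.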

Compound 3, concentration for 50% growth inhibition: 85 nM
Compound 3: the middle estimate sits 1.1-fold (0.03 log units) below what was measured; low and high end bracket the measured number.
By their numbers in this assay, from the lowest: compounds 1, 3 and 2 (each within the scatter of the next).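

In this assay, replacing the hydroxyl-ended chains with 1-amino-1-methylethyl gives a 1.3-fold lower number from compound 2 to compound 3 (0.11 log units; within the scatter) and a 1.4-fold higher number from compound 1 to compound 3 (0.14 log units; within the scatter). On a saturated chain carbon bound to a sulfur, then, these three compounds show that a branched chain ending in an amine reads the same as the hydroxyalkyl chains. Compound 3 changes both the end group and the branching, so the part played by each stays unresolved. On these data alone, whether an unbranched aminoethyl chain, a carboxylic acid or a longer chain would step beyond the scatter also stays open. No evidence is available to explain this result.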